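A few compounds are considered here, and "the series" means these few. Any claim that something is new, unique, unknown or untested is made for them only; others in the source may bear on it.

For the measured compounds named here, compound 1 `CC(=O)N1N=C(c2ccc3ccccc3c2)OC1c1ccccc1` stands at the lower of the two numbers measured so far. In a functional assay on B16-F10 cells (Mus musculus) for antiproliferative activity, read by MTT assay, with a stated time of 48 h (on this read-out higher numbers stand for weaker inhibition and lower numbers for stronger inhibition), compound 1 gives 2.57 ug/mL. Going by the values given here, its only measured neighbour is compound 2 `COc1ccc(C2OC(c3ccc4ccccc4c3)=NN2C(C)=O)cc1`, which in this assay gives 6.86 ug/mL; the single change between them, methoxy in place of hydrogen on an aromatic carbon, produced a 2.7-fold higher number from compound 1 to compound 2 (0.43 log units; beyond the scatter). Compound 3 `CC(=O)N1N=C(c2ccc3ccccc3c2)OC1c1ccc(F)cc1` has not yet been measured. It differs from compound 1 by fluoro in place of hydrogen on an aromatic carbon. Among the compounds with values here, the step to compound 2 is the only guide, and it bears on the present change only loosely, since methoxy is a different and larger group than fluoro. Compound 3 is therefore expected to show a 1.4-fold higher number from compound 1 to compound 3 (0.13 log units; within the scatter), a step close to the scatter, leaning toward a higher number if anything. The estimate for compound 3 in this assay is 3.5 ug/mL, with a range from 1.5 ug/mL to 8 ug/mL.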

Compound 3, half-maximal inhibitory concentration: 4.65 ug/mL
Compound 3: middle estimate off by 1.3-fold (0.12 log units), on the low side; measured number inside the range.
By their numbers in this assay, from the lowest: compounds 1, 3 and 2 (each within the scatter of the next, the first and the last beyond it).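

In this assay, fluoro in place of hydrogen on this six-membered aromatic ring gives a 1.8-fold higher number from compound 1 to compound 3 (0.26 log units; within the scatter) and so, unlike the methoxy change, does not move the number clear of the scatter. Fluoro in place of methoxy at this same place gives a 1.5-fold lower number from compound 2 to compound 3 (0.17 log units; within the scatter) and so does not separate these two groups either, which leaves compound 3 within the scatter of both neighbours while only compound 1 and compound 2 stand apart. Nothing available explains these steps, and no cause can be assigned to them.

Still open, on these data alone, is whether a chloro, nitro or amino group at this place would give a number beyond the scatter of compound 1 in either direction. Also open, as far as these compounds go, is whether a hydroxyl group or a longer alkoxy chain would follow methoxy or fluoro here.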